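Moving the pyridine nitrogen in a weak antiproliferative series

The source may hold more compounds than are shown below. What is called first, only, known or untested is meant among the compounds shown, and "the series" means these compounds.

Compound 1 `Cc1cn2c(/C=N/NC(=N)N)c(-c3ccncc3)nc2s1` was tested in a functional assay on renal cells (Homo sapiens) for antiproliferative activity (on this read-out lower numbers stand for stronger inhibition of growth and higher numbers for weaker inhibition of growth), and gave 23400 nM. For the measured compounds named here, its one measured neighbour, compound 2 `Cc1sc2nc(-c3ccncc3)c(/C=N/NC(=N)N)n2c1C`, gave 39800 nM; the only step among the measured pair, a 1.7-fold higher number from compound 1 to compound 2 (0.23 log units; within the scatter), comes from a methyl in place of hydrogen on an aromatic carbon and does not separate the two compounds beyond the scatter. Compound 3 `Cc1cn2c(/C=N/NC(=N)N)c(-c3cccnc3)nc2s1` has not yet been measured. It differs from compound 1 by pyridin-3-yl in place of pyridin-4-yl on an aromatic carbon. Going by the values given here, no measured step touches this part of the shared core, so the single available step says nothing direct about the pyridin-3-yl change, and the scatter of the measurement itself is the main guide. Compound 3 is therefore expected to give about 25000 nM in this assay, meaning a 1.1-fold higher number from compound 1 to compound 3 (0.03 log units; within the scatter) as the estimated step, with a range of roughly 8000 nM to 80000 nM around it.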

Compound 3, concentration for 50% growth inhibition: 9550 nM
Beside the measured number, compound 3's estimate is 2.6-fold (0.42 log units) above it; low and high end bracket the measured number.
By their numbers in this assay, from the lowest: compound 3; then compounds 1 and 2 (each within the scatter of the next).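

In this assay, pyridin-3-yl in place of pyridin-4-yl gives a 2.5-fold lower number from compound 1 to compound 3 (0.39 log units; beyond the scatter), a modest step but the only one in the series that lies beyond the scatter. The two compounds have the same atoms, joined differently, so this aromatic carbon of the shared core is a place where the way the pyridine ring is attached alone changes the read-out, which the methyl step from the earlier pair could not show. Nothing available explains the change in the number.

On these data alone, it remains open whether phenyl, with no ring nitrogen, or pyridin-2-yl at this place would give a lower or a higher number than either pyridine. As far as these compounds go, it is also open whether the added methyl, which separated nothing in the pyridin-4-yl pair, would behave the same way on the pyridin-3-yl compound.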